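Acetyl in place of carboxymethyl on the chain

The source may hold more compounds than are shown below. What is called first, only, known or untested is meant among the compounds shown, and "the series" means these compounds.

Compound 2 `CCCn1c(=O)n(C)c(=O)c2c1ncn2CCC(=O)O` was tested in a functional assay (trachea) with Cavia porcellus as the target; on this read-out higher numbers stand for an effect only at larger amounts of compound and lower numbers for an effect already at smaller amounts. In this assay compound 2 gives only a limit, > 100000 nM, not a number. Compound 2 therefore sits at the limit of > 100000 nM in this assay, at which 1 of the 2 values shown sits. Compound 1 `CCCn1c(=O)n(CC(=O)O)c(=O)c2[nH]cnc21`, whose two chains are arranged differently, gives 41000 nM in this assay. Compound 3 `CCCn1c(=O)n(C)c(=O)c2c1ncn2CC(C)=O` has not yet been measured; it differs from compound 2 by acetyl in place of carboxymethyl on a saturated chain carbon bound to an aromatic nitrogen. For the measured compounds named here, no step between measured compounds is available, so the change is expected to shift the read-out toward somewhat lower numbers, with a limit still possible. Compound 3 is expected to give about 60000 nM, within 15000 nM to 200000 nM. The expected step of an at least 1.6-fold lower number from compound 2 to compound 3 (0.22 log units; that floor lies within the scatter) is an estimate only.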

Compound 3, half-maximal effective concentration: 1900 nM
Compound 3: middle estimate off by 32-fold (1.50 log units), on the high side, and the stated range ends above it.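

In this assay, the group on a saturated chain carbon bound to an aromatic nitrogen proves decisive for the read-out: acetyl in place of carboxymethyl gives an at least 52-fold lower number from compound 2 to compound 3 (1.72 log units; beyond the scatter). Compound 1 differs in more than one place and cannot show this. The true size of the step stays unknown because compound 2 gives only a limit: the limit of > 100000 nM in this assay, at which 1 of the 3 values shown sits.

The compounds shown leave open whether acetyl itself is needed or whether removing carboxymethyl is enough. From the compounds shown here alone, how an amine, an ester or a longer chain would read at this place also remains open.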